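Tracheal Inhibition Along a Side-Chain Exchange

This account rests on a few compounds, and the source may have more. Where it says the series, first, only, none or still open, it means among the compounds named here.

Measured so far in a functional assay (trachea) with Cavia porcellus as the target; on this read-out higher numbers stand for weaker inhibition and lower numbers for stronger inhibition:
compound 1 `CCCCCCCCn1nc(-c2cccnc2)c2ccccc2c1=O` gives 21900 nM
compound 2 `CC(=O)OCCn1nc(-c2cccnc2)c2ccccc2c1=O` gives 9770 nM

Among the compounds with values here, compound 2 holds the lowest of the two numbers, and the only measured step, a 2.2-fold lower number from compound 1 to compound 2 (0.35 log units; beyond the scatter), lies beyond the scatter. Compound 3 `O=c1c2ccccc2c(-c2cccnc2)nn1CCSc1ncccn1` differs from compound 2 by (pyrimidin-2-yl)sulfanyl in place of acetoxy on a saturated chain carbon, two bonds along the chain from an aromatic nitrogen. Within the data shown here, no measured step covers this exchange; the single known step concerns a different group at the same place on the chain and was modest. The expected step for compound 3 is therefore a 1.2-fold lower number from compound 2 to compound 3 (0.09 log units; within the scatter), nothing beyond the scatter. Compound 3 is estimated at 8000 nM, in a range from 3000 nM to 25000 nM.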

Compound 3, half-maximal inhibitory concentration: 11000 nM
Compound 3: middle estimate off by 1.4-fold (0.14 log units), on the low side, within the range that was stated.
By their numbers in this assay, from the lowest: compounds 2, 3 and 1 (each within the scatter of the next, the first and the last beyond it).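

In this assay, (pyrimidin-2-yl)sulfanyl cannot be told apart from acetoxy at this place on the chain, with a 1.1-fold higher number from compound 2 to compound 3 (0.05 log units; within the scatter) as the exchange. Against hexyl the same group gives a 2.0-fold lower number from compound 1 to compound 3 (0.30 log units; within the scatter) and so also stays within the scatter, although compound 2 stands beyond it from compound 1. A six-membered aromatic ring with two hetero atoms is thus accommodated here without a readable change from acetoxy, and no evidence on the reason for this result is available.

As far as these compounds go, whether an amine or a carboxylic acid in this place would move the number beyond the scatter remains open. So does the outcome for a plain phenyl ring on the same sulfur.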